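The compounds below may be only part of what the source reports. "The series", "measured", "known", "first", "only" and "open" are said of these compounds alone.

Compound 1 `CC(C)(C)c1cnc(CSc2cnc(Nc3ccccn3)s2)o1`: 10 nM
Compound 2 `CC(C)(C)c1cnc(CSc2cnc(Nc3ccccc3)s2)o1`: 140 nM
Compound 3 `CC(=O)Nc1ncc(SCc2ncc(C(C)(C)C)o2)s1`: not yet measured

Going by the values given here, in a functional assay on A2780 cells (Homo sapiens) for cytotoxicity (on this read-out higher numbers stand for weaker inhibition and lower numbers for stronger inhibition), compound 2 gives 140 nM, the higher of the two numbers so far. Compound 3 differs from it as follows: acetyl in place of phenyl on a nitrogen on an aromatic ring. In short, this is acetyl in place of phenyl on a nitrogen on an aromatic ring, or anilino to acetamido. Among the compounds with values here, one measured step bears on this place: a 14-fold higher number from compound 1 to compound 2 (1.15 log units; beyond the scatter), which is large and beyond the scatter. Within the data shown here, that step exchanges one ring for another, and no measured compound lacks a ring here, so it is only a loose guide. A moderate step towards a higher number is expected in this assay, although a lower number cannot be ruled out. The estimated change is a 2.1-fold higher number from compound 2 to compound 3 (0.33 log units; beyond the scatter). The expected value for compound 3 is 300 nM, with an estimated range of 80 nM to 1200 nM.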

Compound 3, half-maximal inhibitory concentration: 50 nM
For compound 3 the middle estimate is 6.0-fold (0.78 log units) above the measured one; the measured number lies below the stated range.
By their numbers in this assay, from the lowest: compound 1; then compound 3; then compound 2.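

Read in this assay, the change gives a 2.8-fold lower number from compound 2 to compound 3 (0.45 log units; beyond the scatter) and so shows that, on this nitrogen, an aromatic ring is not needed to reach a lower number: acetyl, with no ring, does better than phenyl. Pyridin-2-yl still keeps the lowest number of the three, with a 5.0-fold higher number from compound 1 to compound 3 (0.70 log units; beyond the scatter) in the exchange for acetyl, so the order at this place does not simply follow the presence of a ring, since the two ring groups fall on either side of acetyl. No measurement at hand accounts for this order.

Open, going by these compounds, is whether the carbonyl of the acetyl group matters or only the loss of phenyl: the free amine or an N-methyl amine would separate the two. A longer acyl chain such as propanoyl, or a benzoyl group, would show how much room the amide leaves.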